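Dienone coumarin triazole series: methoxy removal on the aryl ring

The source may report more compounds than this note shows. Statements on the series, on what has been measured and on what is new or still open speak of the compounds shown alone.

Measured so far:
compound 1 `COc1cccc(/C=C/C(=O)/C=C/c2ccc(OCc3cn(CCCOc4cc(=O)oc5ccccc45)nn3)c(OC)c2)c1`; in a functional assay on HCT-116 cells (Homo sapiens) for inhibition, read by sulforhodamine B assay, with a stated time of 48 h, tested at 50 uM (on this read-out lower numbers stand for less inhibition of growth and higher numbers for more inhibition of growth at the one concentration tested), compound 1 gives 55%
compound 2 `COc1ccccc1/C=C/C(=O)/C=C/c1ccc(OCc2cn(CCCCCOc3cc(=O)oc4ccccc34)nn2)c(OC)c1`; compound 2 gives 33%
compound 3 `COc1ccc(/C=C/C(=O)/C=C/c2ccc(OCc3cn(CCCOc4cc(=O)oc5ccccc45)nn3)c(OC)c2)cc1OC`; compound 3 gives 67%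

One matched step is measured. From compound 3 to compound 1 the change is hydrogen in place of methoxy on an aromatic carbon, and it gives a number 12 percentage points lower from compound 3 to compound 1 (beyond the scatter). Compound 2 stands lowest of the three, beyond the scatter of both others. The difference between the core of compound 2 and the core of compound 3 is not broken down here.

Compound 4 `COc1cc(/C=C/C(=O)/C=C/c2ccccc2)ccc1OCc1cn(CCCCCOc2cc(=O)oc3ccccc23)nn1` is not yet measured. Relative to compound 2 the change is hydrogen in place of methoxy on an aromatic carbon. This is the same kind of change as from compound 3 to compound 1, but the surroundings differ: in the measured pair the carbon is ortho to a methoxy group and para to a large group, whereas in compound 4 it is ortho to a large group. Going by the values given here, the only guide is the single measured step of a number 12 percentage points lower from compound 3 to compound 1 (beyond the scatter), so the expectation is tentative. Compound 4 is expected to fall somewhat under compound 2, by about a number 9 percentage points lower from compound 2 to compound 4 (within the scatter). Compound 4 is estimated at 24% in this assay, within a range of 8% to 40%.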

Compound 4, percent growth inhibition at one concentration: 24%
Estimate against measurement, compound 4: no gap at the digits printed; the range from low to high includes it.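

In this assay, hydrogen in place of methoxy on an aromatic carbon gives a number 9 percentage points lower from compound 2 to compound 4 (within the scatter), and set beside the earlier step, the change reads alike on the two cores: the same change on two cores in this assay, a number 12 percentage points lower (beyond the scatter) from compound 3 to compound 1 and a number 9 percentage points lower (within the scatter) from compound 2 to compound 4, 3 percentage points apart, within the scatter of two such steps The change therefore carries from the core of compound 3 to the core of compound 2 with no size difference that can be told apart, but only the earlier step stands clear of the scatter on its own, so compound 2 and compound 4 cannot be ranked. This does not establish a general size for the change, since it rests on two pairs at one concentration, and the carbon involved has different surroundings in each pair.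

Still open, on these data alone, is how a hydroxyl or an amine in place of the methoxy would read on either core. Going by these compounds alone, also open is whether a chain longer than the one in compound 2 would leave the step unchanged.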